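A few compounds are considered here, and "the series" means these few. Any claim that something is new, unique, unknown or untested is made for them only; others in the source may bear on it.

Compound 1 `CS(=O)(=O)NC(=O)CCc1cn(-c2ccccc2)nc1-c1ccc(Cl)cc1` gives 200000 nM in a physicochemical assay for solubility, in phosphate buffer, measured as thermodynamic solubility, at pH 7.4 (a higher number here means a more soluble compound, a lower number a less soluble compound), the highest of the two numbers recorded there; compound 3 `CS(=O)(=O)NC(=O)CCc1cn(-c2ccccc2Br)nc1-c1ccc(Cl)cc1` stands nearest with 165000 nM. For compound 2 `CS(=O)(=O)NC(=O)CCc1cn(-c2cccc(Br)c2)nc1-c1ccc(Cl)cc1` this assay reports only a limit, < 5000 nM. Two measured steps start from compound 1, and each puts bromo in place of hydrogen on an aromatic carbon: an at least 40-fold lower number from compound 1 to compound 2 (1.60 log units; beyond the scatter), whereas a 1.2-fold lower number from compound 1 to compound 3 (0.08 log units; within the scatter). Between the two bromo compounds, an at least 33-fold higher number from compound 2 to compound 3 (1.51 log units; beyond the scatter). One of the three values sits at the limit of < 5000 nM in this assay, at which 1 of the 3 values shown sits.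

Compound 4 `CS(=O)(=O)NC(=O)CCc1cn(-c2ccc(C#N)cc2)nc1-c1ccc(Cl)cc1` has not been measured. It differs from compound 1 by cyano in place of hydrogen on an aromatic carbon, on an aromatic carbon of a six-membered aromatic ring of carbon only, para to a large group. Within the data shown here, no measured step places a group there, so the two bromo steps bear on it only as a caution: one substituent on this ring left the number unchanged, another drove it to the limit. A broad expectation follows. Compound 4 is expected to give about 60000 nM, within 5000 nM to 200000 nM. The expected step is a 3.3-fold lower number from compound 1 to compound 4 (0.52 log units; beyond the scatter), a move downward but short of the limit seen for compound 2.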

Compound 4, solubility: 75000 nM
Compound 4: the middle estimate sits 1.3-fold (0.10 log units) below what was measured, within the range that was stated.
By their numbers in this assay, from the lowest: compound 4; then compounds 3 and 1 (each within the scatter of the next). At a limit, below all of these: compound 2.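

In this assay the change from phenyl to 4-cyanophenyl gives a 2.7-fold lower number from compound 1 to compound 4 (0.43 log units; beyond the scatter) as a modest step, the first measured at this aromatic carbon, para to a large group. Here a substituent lowers the number beyond the scatter yet stops well short of the limit, whereas the bromo of compound 3 stayed within the scatter of compound 1. The new compound also stands apart from the 2-bromophenyl compound, with a 2.2-fold lower number from compound 3 to compound 4 (0.34 log units; beyond the scatter) as a modest step, and compound 2 offers only a limit rather than a number, so the large step of an at least 15-fold higher number from compound 2 to compound 4 (1.17 log units; beyond the scatter) is bounded on one side: the limit of < 5000 nM in this assay, at which 1 of the 4 values shown sits.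

The compounds shown leave open whether this modest step belongs to cyano itself or to any group at this place, since an amine, a carboxylic acid or a methoxy group there could fall anywhere relative to compound 4. They also leave open how cyano would read on the aromatic carbons that carry bromo in compound 2 and compound 3, and how bromo would read para to a large group.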